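A few compounds are considered here, and "the series" means these few. Any claim that something is new, unique, unknown or untested is made for them only; others in the source may bear on it.

Measured so far in a functional assay on HCT-116 cells (Homo sapiens) for inhibition, read by MTT assay, with a stated time of 48 h; on this read-out higher numbers stand for weaker inhibition and lower numbers for stronger inhibition
compound 1 (`C#CC(=O)N(Cc1ccc(OC)c(O)c1)c1cc(OC)c(OC)c(OC)c1`) gives 310 nM
compound 2 (`COc1ccc(CN(C(=O)CO)c2cc(OC)c(OC)c(OC)c2)cc1O`) gives 520 nM

Among the compounds with values here, compound 2 stands level with compound 1 within the scatter, with a 1.7-fold higher number from compound 1 to compound 2 (0.22 log units; within the scatter) as the only step available so far. Next is compound 3 (`COc1ccc(CN(C(=O)CCl)c2cc(OC)c(OC)c(OC)c2)cc1O`), which carries chloro in place of hydroxy on a saturated chain carbon bound to a carbonyl carbon, that is, hydroxymethyl to chloromethyl. Within the data shown here, only one measured step bears on this place, namely hydroxymethyl in place of ethynyl on a carbonyl carbon (a 1.7-fold higher number from compound 1 to compound 2 (0.22 log units; within the scatter)), and it stayed within the scatter. Among the measured compounds shown here, that is a different exchange, and no measured pair compares chloro with hydroxy, so the basis is thin. No step beyond the scatter is therefore expected in this assay for this change, and no direction can be firmly assigned. The expected step is a 1.3-fold lower number from compound 2 to compound 3 (0.11 log units; within the scatter) and this estimate carries a wide margin. For compound 3 the estimated value is 400 nM and the expected range runs from 130 nM to 1200 nM on present evidence.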

Compound 3, half-maximal inhibitory concentration: 250 nM
The estimate for compound 3 lay 1.6-fold (0.20 log units) above the measured number; low and high end bracket the measured number.
By their numbers in this assay, from the lowest: compounds 3, 1 and 2 (each within the scatter of the next, the first and the last beyond it).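

In this assay, within the data shown here, this is the first direct exchange on the saturated chain carbon bound to a carbonyl carbon, and chloro in place of hydroxy gives a modest step beyond the scatter (a 2.1-fold lower number from compound 2 to compound 3 (0.32 log units; beyond the scatter)), whereas the only earlier step bearing on this place stayed within it. Chloromethyl and ethynyl on the carbonyl carbon cannot be told apart in this assay (a 1.2-fold lower number from compound 1 to compound 3 (0.09 log units; within the scatter)), so among the groups compared at this place, only the hydroxymethyl to chloromethyl pair is separated beyond the scatter, and only modestly. No measurement is available that would explain this step.

The compounds shown leave open whether this step is particular to chloro or would also appear with a bromo, a fluoro or an amine on the same saturated chain carbon, or with a longer chain in place of chloromethyl. Also open, on these data alone, is whether the gap between hydroxymethyl and chloromethyl would persist on any other read-out, as the comparison so far rests on a single pair in a single assay.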